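The source may hold more compounds than are shown below. What is called first, only, known or untested is meant among the compounds shown, and "the series" means these compounds.

In a functional assay on ECa-109 cells for inhibition, with ECa-109 cell line (Homo sapiens) as the target, read by sulforhodamine B assay (on this read-out higher numbers stand for weaker inhibition and lower numbers for stronger inhibition), three compounds built on one shared core have been measured. Compound 1 `Cc1ccc(NC2=CC(=O)c3nc4n(c3C2=O)[C@H]2OC[C@@H](O)[C@H]2OC4)cc1C` gives 2820 nM. Compound 3 `COc1cccc(NC2=CC(=O)c3nc4n(c3C2=O)[C@H]2OC[C@@H](O)[C@H]2OC4)c1` gives 7620 nM, and the change between them, 3-methoxyphenyl in place of 3,4-dimethylphenyl on an amine nitrogen, brings a 2.7-fold higher number from compound 1 to compound 3 (0.43 log units; beyond the scatter). Compound 2 `CCCc1ccc(NC2=CC(=O)c3c(nc4n3[C@H]3OC[C@@H](O)[C@H]3OC4)C2=O)cc1` is known only as a limit of the assay, > 4000 nM. Its standing among the measured numbers is therefore open; it sits at the limit of > 4000 nM in this assay, at which 1 of the 3 values shown sits, and nothing more precise is known of it.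

Compound 4 `COc1ccccc1NC1=CC(=O)c2c(nc3n2[C@H]2OC[C@@H](O)[C@H]2OC3)C1=O` differs from compound 2 in one place: 2-methoxyphenyl in place of 4-propylphenyl on an amine nitrogen. Going by the values given here, no measured step matches this exact change. The nearest guide is the modest step from compound 1 to compound 3 on moving to a methoxyphenyl, and compound 3, itself a methoxyphenyl analogue, stands at 7620 nM. A weak result in the same region is expected, with a step that the limit leaves unreadable from compound 2 to compound 4 expected to be small. For compound 4 an inhibitory concentration of 6000 nM is estimated, with a range from 2500 nM to 15000 nM.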

Compound 4, half-maximal inhibitory concentration: > 4000 nM
Compound 4: a limit, no number; the forecaster's own chance of this, stated with the estimate: 35%; the middle value is on the limit's open side.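

No step can be read from compound 2 to compound 4, because both are known only as limits: the limit of > 4000 nM in this assay, at which 2 of the 4 values shown sit.

Still open, on these data alone, is whether 2-methoxyphenyl or 4-propylphenyl on the amine nitrogen gives stronger inhibition, and how far either compound really stands from compound 1 and compound 3.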